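This account rests on a few compounds, and the source may have more. Where it says the series, first, only, none or still open, it means among the compounds named here.

In an ADME assay on L02 cells (Homo sapiens) for antiproliferative activity, read by MTT assay, with a stated time of 48 h (on this read-out lower numbers stand for stronger inhibition and higher numbers for weaker inhibition), compound 2 (`CCn1c(C(=O)N(CCC#N)CCC#N)ccc1C(CC)(CC)c1ccc(OCCC(O)(CC)CC)c(C)c1`) gives 37800 nM, the higher of the two numbers measured. Compound 1 (`CCn1c(C(=O)NCCCN(C)C)ccc1C(CC)(CC)c1ccc(OCCC(O)(CC)CC)c(C)c1`) gives 2420 nM, which makes a 16-fold higher number from compound 1 to compound 2 (1.19 log units; beyond the scatter). Compound 3 (`CCn1c(C(=O)Nc2cccc(C(F)(F)F)c2)ccc1C(CC)(CC)c1ccc(OCCC(O)(CC)CC)c(C)c1`) gives > 50000 nM, which is a limit of the assay. Compound 4 (`CCOc1ccc(NC(=O)c2ccc(C(CC)(CC)c3ccc(OCCC(O)(CC)CC)c(C)c3)n2CC)cc1`) differs from compound 2 by a group of 10 heavy atoms (8 carbon, 1 nitrogen, 1 oxygen; one six-membered aromatic ring of carbon only) in place of a group of 9 heavy atoms (6 carbon, 3 nitrogen; no ring), on a carbonyl carbon, with (4-ethoxyphenyl)amino entering on the carbonyl carbon. The closest measured change also brings a six-membered aromatic ring of carbon only: an at least 1.3-fold higher number from compound 2 to compound 3 (0.12 log units; that floor lies within the scatter), a floor within the scatter. The large at least 20-fold higher number from compound 1 to compound 3 (1.31 log units; beyond the scatter) starts from a different group and bears less directly. The expected change is a 1.0-fold higher number from compound 2 to compound 4 (0.00 log units; within the scatter), with no step beyond the scatter anticipated. The value expected for compound 4 is 38000 nM, estimated to lie between 15000 nM and 50000 nM.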

Compound 4, half-maximal inhibitory concentration: > 50000 nM
Compound 4: no number, only a limit; the forecaster's own chance of this, stated with the estimate: 50%; at least 1.3-fold (0.11 log units) between middle value and limit.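

Compound 4 shows that a second substituted phenyl on the amide-type nitrogen, 4-ethoxyphenyl instead of 3-(trifluoromethyl)phenyl, also gives a limit and not a number in this assay: the limit of > 50000 nM in this assay, at which 2 of the 4 values shown sit. Replacing 3-(dimethylamino)propyl gives an at least 20-fold higher number from compound 1 to compound 4 (1.31 log units; beyond the scatter), while replacing the nitrile-bearing group gives an at least 1.3-fold higher number from compound 2 to compound 4 (0.12 log units; that floor lies within the scatter). The step between compound 3 and compound 4 cannot be read, as both values are limits.

On these data alone, it remains open whether a phenyl carrying a dimethylamino group on the amide-type nitrogen would give a measurable number. As far as these compounds go, a shorter amine chain or a carboxylic acid there also remains open.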